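Chain length at the pyridine of a piperazinyl series

The compounds below may be only part of what the source reports. "The series", "measured", "known", "first", "only" and "open" are said of these compounds alone.

Measured compounds:
compound 1 `CCCCCCCc1cccc(N2CCNCC2)n1` gives 10 mg/kg
compound 2 `c1ccc(CCc2cccc(N3CCNCC3)n2)cc1` gives > 300 mg/kg
compound 3 `CCCCCCCCCCc1cccc(N2CCNCC2)n1` gives 30 mg/kg

In a functional assay on the whole organism with Mus musculus as the target, in the maximal electroshock model, with a stated time of 120 min (on this read-out higher numbers stand for an effect only at larger amounts of compound and lower numbers for an effect already at smaller amounts), compound 3 holds the highest of the two numbers that were obtained; the nearest is compound 1, and the step of a 3.0-fold higher number from compound 1 to compound 3 (0.48 log units; beyond the scatter) goes with propyl in place of hydrogen on a saturated chain carbon, seven bonds along the chain from an aromatic carbon. Compound 2 reaches only a limit of the assay, (the limit of > 300 mg/kg in this assay, at which 1 of the 3 values shown sits). The step of an at least 30-fold higher number from compound 1 to compound 2 (1.47 log units; beyond the scatter) is therefore known only as a lower bound.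

Compound 4 `CCCCc1cccc(N2CCNCC2)n1` is not yet measured. It differs from compound 3 by hydrogen in place of hexyl on a saturated chain carbon, four bonds along the chain from an aromatic carbon. Among the compounds with values here, the only measured step that bears on it is the chain lengthening from compound 1 to compound 3, which was modest and raised the number; the present step goes the other way and cuts deeper, so a modest change in either direction, or none beyond the scatter, is conceivable. A slight lowering is expected, as the step of a 2.0-fold lower number from compound 3 to compound 4 (0.30 log units; within the scatter) indicates. For compound 4 the estimate in this assay is 15 mg/kg, within 5 mg/kg to 60 mg/kg.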

Compound 4, minimum effective dose: 30 mg/kg
Estimate against measurement, compound 4: 2.0-fold (0.30 log units) below; measured number inside the range.
By their numbers in this assay, from the lowest: compound 1; then compounds 3 and 4 (each within the scatter of the next). At a limit, above all of these: compound 2.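

In this assay, hydrogen in place of hexyl leaves the result flat, with no change at the digits printed from compound 3 to compound 4 (within the scatter), while a 3.0-fold higher number from compound 1 to compound 4 (0.48 log units; beyond the scatter) shows that a shorter chain also costs against compound 1. Among compounds 1, 3 and 4, chain length therefore does not move the number in one direction: compound 1 lies under both the shorter chain of compound 4 and the longer chain of compound 3. The step of an at least 10-fold lower number from compound 2 to compound 4 (1.00 log units; beyond the scatter) goes with ethyl in place of phenyl and rests on a limit, the one held by compound 2: the limit of > 300 mg/kg in this assay, at which 1 of the 4 values shown sits.

Open, as far as these compounds go, is how sharply the number turns around compound 1, which a hexyl or an octyl chain at this place would settle. Also open, from the compounds shown here alone, is whether a phenyl further out on a longer chain, or an amine at the chain end, would be tolerated.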